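Piperidine side-chain variation on the furan amide series

The source may report more compounds than this note shows. Statements on the series, on what has been measured and on what is new or still open speak of the compounds shown alone.

Measured so far:
compound 1 `Cn1ncc(Cl)c1-c1cc(C(=O)NC2CNCCC2c2ccc(C(F)(F)F)cc2)oc1Cl` gives 7.2 nM in an assay for inhibition of RAC-alpha serine/threonine-protein kinase (Homo sapiens), read by HTRF, with a stated time of 1 h; a higher number here means a weaker inhibitor, a lower number a stronger inhibitor
compound 2 `Cn1ncc(Cl)c1-c1cc(C(=O)N[C@@H]2CN[C@H](CCn3cncn3)C[C@H]2c2ccc(Cl)c(Cl)c2)oc1Cl` gives 4.47 nM in this assay
compound 3 `CNC(=O)C[C@@H]1C[C@@H](c2ccc(F)c(F)c2)[C@H](NC(=O)c2cc(-c3c(Cl)cnn3C)c(Cl)o2)CN1` gives 1.37 nM in this assay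

All three share the same core; they differ in the aryl ring on the piperidine and in what, if anything, hangs from the ring carbon next in the chain. Compound 2 stands second highest of the three numbers. Its nearest neighbour is compound 1, whose number is higher by an amount that stays within the scatter of the measurement; its furthest is compound 3, whose number is lower by an amount beyond the scatter. Within the data shown here, no pair among the measured compounds differs in a single place, so no step can be isolated.

Compound 4 `Cn1ncc(Cl)c1-c1cc(C(=O)N[C@@H]2CN[C@H](CCN3CCCC3)C[C@H]2c2ccc(Cl)c(Cl)c2)oc1Cl` has not yet been measured. It is derived from compound 2 by one change: pyrrolidin-1-yl in place of 1H-1,2,4-triazol-1-yl on a saturated chain carbon, two bonds along the chain from a saturated ring carbon. Among the measured compounds shown here, the measured compounds give no direct step for this exchange. The side chain at this position tolerates variation, as compound 1 (none) and compound 3 (a different chain) show, so no step beyond the scatter is expected for a 1.0-fold higher number from compound 2 to compound 4 (0.00 log units; within the scatter). Compound 4 is accordingly estimated at 4.5 nM, with a range from 1.5 nM to 13 nM.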

Compound 4, half-maximal inhibitory concentration: 6.41 nM
Compound 4: the middle estimate sits 1.4-fold (0.15 log units) below what was measured; measured number inside the range.
By their numbers in this assay, from the lowest: compound 3; then compounds 2, 4 and 1 (each within the scatter of the next).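

Pyrrolidin-1-yl in place of 1H-1,2,4-triazol-1-yl on a saturated chain carbon, two bonds along the chain from a saturated ring carbon, gives in this assay a 1.4-fold higher number from compound 2 to compound 4 (0.16 log units; within the scatter) and is the first exchange in the series read in one place alone. Among these compounds, at this position, the 2-(1H-1,2,4-triazol-1-yl)ethyl and 2-(pyrrolidin-1-yl)ethyl chains stay within the scatter of each other, although the end group goes from a five-membered aromatic ring with 3 hetero atoms and 3 hydrogen-bond acceptors to a five-membered non-aromatic ring with 1 hetero atom and 1 hydrogen-bond acceptor, whereas the earlier compounds differed in more than one place and could not separate this end group from the rest. No supporting measurement is at hand to account for this result.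

From the compounds shown here alone, whether a carboxylic acid, a primary amine or a longer chain in this place would also stay within the scatter of compound 2 remains open. Among the compounds shown here, also open is whether the same exchange would give a similar step with the aryl ring of compound 3 in place of the one in compound 2.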